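Three aryl variants on a shared core, and a fourth

A few compounds are considered here, and "the series" means these few. Any claim that something is new, unique, unknown or untested is made for them only; others in the source may bear on it.

Compound 1 `COc1ccc(-c2nnc(SCCn3c([N+](=O)[O-])cnc3C)o2)cc1` is the reference point of this series. Among the measured compounds shown here, in a functional assay on SGC-7901 cells (Homo sapiens) for cytotoxicity, read by MTT assay, with a stated time of 48 h (on this read-out lower numbers stand for stronger inhibition and higher numbers for weaker inhibition), compound 1 gives 10200 nM, the lowest of the three numbers measured so far. Its nearest neighbour is compound 2 `Cc1ncc([N+](=O)[O-])n1CCSc1nnc(-c2ccccc2Cl)o1`, which gives 32600 nM; the change between them is a 3.2-fold higher number from compound 1 to compound 2 (0.50 log units; beyond the scatter), 2-chlorophenyl in place of 4-methoxyphenyl on an aromatic carbon. Compound 3 `COc1cc(-c2nnc(SCCn3c([N+](=O)[O-])cnc3C)o2)cc(OC)c1OC` gives 34800 nM, so its number sits close to that of compound 2 and well above that of compound 1.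

Compound 4 `Cc1ncc([N+](=O)[O-])n1CCSc1nnc(-c2cnccc2N)o1` has not yet been measured. Compared with compound 1 it differs in one place: 4-aminopyridin-3-yl in place of 4-methoxyphenyl on an aromatic carbon. For the measured compounds named here, the only measured step that bears on this position is the one from compound 1 to compound 2, where swapping the 4-methoxyphenyl for another aryl group raised the number by a modest but clear margin. Both measured replacements of the 4-methoxyphenyl on this core, in compound 2 and compound 3, gave higher numbers, so a similar shift upward is expected here as well, though with little to anchor how large. Compound 4 is therefore expected to give about 25000 nM, between 8000 nM and 80000 nM, corresponding to an expected step of a 2.5-fold higher number from compound 1 to compound 4 (0.39 log units; beyond the scatter).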

Compound 4, half-maximal inhibitory concentration: 34500 nM
Compound 4: the middle estimate sits 1.4-fold (0.14 log units) below what was measured, within the range that was stated.
By their numbers in this assay, from the lowest: compound 1; then compounds 2, 4 and 3 (each within the scatter of the next).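

In this assay, 4-aminopyridin-3-yl in place of 4-methoxyphenyl gives a 3.4-fold higher number from compound 1 to compound 4 (0.53 log units; beyond the scatter), so a replacement with a ring hetero atom and a hydrogen-bond donor also ends higher than compound 1, and none of the replacements shown goes against this. Set against the 2-chlorophenyl group, the same aryl group gives a 1.1-fold higher number from compound 2 to compound 4 (0.02 log units; within the scatter), so this assay does not separate these two groups at this position, even though they differ in their ring atoms and in their hydrogen-bond donors. The data shown offer no measurement that accounts for compound 1 keeping the lowest number of the four.

The compounds shown leave open whether the methoxy group matters at all, as a plain phenyl group would show how much of the number of compound 1 depends on it. They also leave the ring nitrogen and the amine of compound 4 unseparated, and a pyridin-3-yl group without the amine, set beside a phenyl group carrying an amine, would divide this step between them.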